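Notes on the step from compound 2 to compound 4

The source may report more compounds than this note shows. Statements on the series, on what has been measured and on what is new or still open speak of the compounds shown alone.

In a functional assay on MCF7 cells (Homo sapiens) for antiproliferative activity, read by MTT assay, with stated times of 24 h and 72 h (on this read-out higher numbers stand for weaker inhibition and lower numbers for stronger inhibition), compound 1 (`COc1ccc([C@@H]2[C@H](Oc3ccccc3)C(=O)N2c2cc(OC)c(OC)c(OC)c2)cc1`) gives 35000 nM, compound 2 (`COc1ccc([C@@H]2[C@@H](Oc3ccccc3)C(=O)N2c2cc(OC)c(OC)c(OC)c2)cc1`) gives 6900 nM and compound 3 (`COc1ccc(N2C(=O)[C@@H](Oc3ccccc3)[C@H]2c2ccc(OC)c(O)c2)cc1`) gives 49000 nM. Compound 2 therefore holds the lowest number of the three, and its gaps to both others lie beyond the scatter.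

Compound 4 (`COc1ccc([C@@H]2[C@@H](Oc3ccccc3)C(=O)N2c2cc(OC)c(OC)c(OC)c2)cc1NC(=O)C(C)N`) departs from compound 2 in one place: ((1-aminoethyl)carbonyl)amino in place of hydrogen on an aromatic carbon. The entering group is ((1-aminoethyl)carbonyl)amino, in place of hydrogen on an aromatic carbon.

Within the data shown here, only one measured step is available, a 5.1-fold lower number from compound 1 to compound 2 (0.71 log units; beyond the scatter), and it concerns configuration alone because of the fact that compounds 1 and 2 differ only in the configuration as drawn. Compound 4 keeps the configuration drawn for compound 2, so that step gives no size for a new substituent. Among the measured compounds shown here, no measured step covers such a substitution, so no direction can be firmly expected in this assay, and a shift beyond the scatter is not the central expectation.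

The expected change is a 1.4-fold lower number from compound 2 to compound 4 (0.14 log units; within the scatter). For compound 4 the estimated value is 5000 nM, with an expected range of 600 nM to 40000 nM.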

Compound 4, half-maximal inhibitory concentration: 230 nM
Compound 4: the middle estimate sits 22-fold (1.34 log units) above what was measured; the whole stated range lies above it.
By their numbers in this assay, from the lowest: compound 4; then compound 2; then compounds 1 and 3 (each within the scatter of the next).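

This position, an aromatic carbon ortho to a methoxy group and meta to a large group, accepts a substituent without loss of activity: in this assay, ((1-aminoethyl)carbonyl)amino in place of hydrogen gives a 30-fold lower number from compound 2 to compound 4 (1.48 log units; beyond the scatter), a large step. Among these compounds, the earlier compounds offered only one readable step, a change of configuration, so this is the first measured sign that substitution on this aromatic carbon can move the number strongly. The compounds shown offer no information that explains the size of this step.

Open, going by these compounds, is whether the whole ((1-aminoethyl)carbonyl)amino group is needed, or whether a plain amine or an acetylamino group on the same carbon would give a similar number. Also open, on these data alone, is how a longer chain would compare at this position, and whether the step carries over to the configuration drawn in compound 1.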